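Hydrazide to cyanoethyl ester: expected shorter half-life

The source may report more compounds than this note shows. Statements on the series, on what has been measured and on what is new or still open speak of the compounds shown alone.

Compound 2 `Cc1cc(/C=C/C#N)cc(C)c1Oc1cc(Nc2ccc(C#N)cc2)c(N)cc1C(=O)NN` sits second highest of the three numbers in an ADME assay on liver (Homo sapiens) for metabolic stability, read by LC-MS, using S9 fraction and NADPH, with a stated time of 45 min, tested at 1 uM (on this read-out lower numbers stand for a shorter-lived compound and higher numbers for a longer-lived compound), where compound 2 gives 0.65 h. Compound 1 `CCNC(=O)c1cc(N)c(Nc2ccc(C#N)cc2)cc1Oc1c(C)cc(/C=C/C#N)cc1C` gives 1.02 h, and a 1.6-fold lower number from compound 1 to compound 2 (0.20 log units; within the scatter) stays within the scatter. Compound 3 `COC(=O)c1cc(N)c(Nc2ccc(C#N)cc2)cc1Oc1c(C)cc(/C=C/C#N)cc1C` gives 0.128 h, with a 5.1-fold lower number from compound 2 to compound 3 (0.71 log units; beyond the scatter) and an 8.0-fold lower number from compound 1 to compound 3 (0.90 log units; beyond the scatter) both beyond the scatter. Compound 4 `Cc1cc(/C=C/C#N)cc(C)c1Oc1cc(Nc2ccc(C#N)cc2)c(N)cc1C(=O)OCCC#N` carries 2-cyanoethoxy in place of aminoamino on a carbonyl carbon. Among the compounds with values here, the one measured step that removes the aminoamino group from that carbonyl carbon, a 5.1-fold lower number from compound 2 to compound 3 (0.71 log units; beyond the scatter), brought a modest drop, and compound 4 likewise carries an alkoxy group on that carbon, so a step of similar size downward is expected in this assay, a 3.3-fold lower number from compound 2 to compound 4 (0.51 log units; beyond the scatter). Compound 4 is therefore estimated at 0.2 h, within a range from 0.08 h to 0.5 h.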

Compound 4, half-life: 0.2 h
Compound 4: middle estimate and measured number agree at the digits printed, within the range that was stated.
By their numbers in this assay, from the lowest: compounds 3 and 4 (each within the scatter of the next); then compounds 2 and 1 (each within the scatter of the next).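

In this assay a second alkoxy group on the carbonyl carbon gives the same picture as the first, with a 3.3-fold lower number from compound 2 to compound 4 (0.51 log units; beyond the scatter) and a 5.1-fold lower number from compound 1 to compound 4 (0.71 log units; beyond the scatter) both beyond the scatter. Going from methoxy to 2-cyanoethoxy on that carbon does not separate the two esters, as a 1.6-fold higher number from compound 3 to compound 4 (0.19 log units; within the scatter) lies within the scatter. Nothing available explains these differences. From the compounds shown here alone, whether a carboxylic acid or a dimethylamide on that carbonyl carbon would sit with the esters or with compound 1 remains open.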